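The source may hold more compounds than are shown below. What is called first, only, known or untested is meant among the compounds shown, and "the series" means these compounds.

Measured compounds, all in a functional assay on DU-145 cells (Homo sapiens) for inhibition, read by trypan blue exclusion, with a stated time of 96 h; a higher number here means a weaker inhibitor of growth, a lower number a stronger inhibitor of growth:
- compound 1 `O=C(/C(=C\c1ccc(Br)cc1)Sc1ccc(Br)cc1)c1ccc(Br)cc1` gives 1000 nM
- compound 2 `Cc1ccc(CS/C(=C/c2c[nH]c3ccc(Br)cc23)C(=O)c2ccc(Cl)cc2)cc1` gives 1000 nM
- compound 3 `O=C(/C(=C\c1c[nH]c2ccc(Br)cc12)SCc1ccc(Cl)cc1Cl)c1ccc(Cl)cc1` gives 10000 nM

Compound 2 stands level with compound 1 at the digits shown, and the two together sit at the lowest number of the three. Within the data shown here, the only compound clearly apart from them is compound 3, reached by a 10-fold higher number from compound 2 to compound 3 (1.00 log units; beyond the scatter) when 2,4-dichlorophenyl takes the place of 4-methylphenyl on a saturated chain carbon bound to a sulfur.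

Compound 4 `Cc1ccc(CS/C(=C/c2c[nH]c3ccc(Cl)cc23)C(=O)c2ccc(Cl)cc2)cc1` is not yet measured. It differs from compound 2 by chloro in place of bromo on an aromatic carbon; cut one bond further out, the change reads 5-bromo-1H-indol-3-yl to 5-chloro-1H-indol-3-yl. Among the measured compounds shown here, no measured step exchanges bromo for chloro at this position, so there is nothing that bears on it directly. For the measured compounds named here, the one measured step concerns a different part of the molecule and a larger exchange of groups. The change here is a single heavy atom for another, with no ring, no donor and no acceptor added or removed, and the expectation is therefore a step of no change at the digits printed from compound 2 to compound 4 (within the scatter), that is, none beyond the scatter. Compound 4 is expected to give about 1000 nM, with a likely range from 400 nM to 2500 nM.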

Compound 4, concentration for 50% growth inhibition: 1000 nM
Compound 4: middle estimate and measured number agree at the digits printed, and the stated range covers the measured number.
By their numbers in this assay, from the lowest: compounds 1, 2 and 4 (each within the scatter of the next); then compound 3.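

Read in this assay, putting chloro in place of bromo on an aromatic carbon, which turns 5-bromo-1H-indol-3-yl into 5-chloro-1H-indol-3-yl, gives no change at the digits printed from compound 2 to compound 4 (within the scatter). Among these compounds, the earlier step concerned a different part of the molecule, the group on a saturated chain carbon bound to a sulfur, so this pair gives the first reading at this position: with the rest of compound 2 kept, one of these halogens can take the place of the other with no difference beyond the scatter. No measurement here explains why the two compounds read alike.

Bromo and chloro are both single halogen atoms, so the compounds shown leave open what happens at this position with plain hydrogen, a methoxy group, an amine or a carboxylic acid. From the compounds shown here alone, it also remains open whether the same exchange would read alike alongside the 2,4-dichlorophenyl group of compound 3, which gives 10000 nM with bromo in place.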